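Piperidine nitrogen substitution and cytotoxicity in the oxalamide series

The compounds below may be only part of what the source reports. "The series", "measured", "known", "first", "only" and "open" are said of these compounds alone.

Compound 1 `Cc1nc(C(NC(=O)C(=O)Nc2ccc(Cl)cc2)C2CCCCN2C)sc1CCO` gives 36000 nM in an ADME assay on TZM-b1 cells (Homo sapiens) for cytotoxicity, read by XTT assay, with a stated time of 3 days; on this read-out higher numbers stand for lower toxicity in this test and lower numbers for higher toxicity in this test.
Compound 2 `CC(=O)N1CCCCC1C(NC(=O)C(=O)Nc1ccc(Cl)cc1)c1nc(C)c(CCO)s1` gives > 84000 nM in this assay.

Compound 2 stands only at a limit of the test, not at a number, so its position is known as a bound rather than a point. Going by the values given here, the single measured step, an at least 2.3-fold higher number from compound 1 to compound 2 (0.36 log units; beyond the scatter), is accordingly itself a bound, because of the limit of > 84000 nM in this assay, at which 1 of the 2 values shown sits.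

Compound 3 `Cc1nc(C(NC(=O)C(=O)Nc2ccc(Cl)cc2)C2CCCNC2)sc1CCO` differs from compound 2 by piperidin-3-yl in place of 1-acetylpiperidin-2-yl on a saturated chain carbon bound to an amide-type nitrogen and an aromatic carbon. Among the compounds with values here, the change removes the acetyl whose introduction marked the step from compound 1 to compound 2, but compound 3 carries neither acetyl nor methyl on the ring nitrogen, and no measured pair covers that case, so the step cannot be read directly from the data. The expectation is that compound 3 moves back toward compound 1 rather than staying at the bound of compound 2, by a modest amount at most, with the direction uncertain.

For compound 3 the estimated value in this assay is 55000 nM, with a range from 25000 nM to 120000 nM. This corresponds to an expected step of an at least 1.5-fold lower number from compound 2 to compound 3 (0.18 log units; that floor lies within the scatter).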

Compound 3, half-maximal cytotoxic concentration: 59400 nM
Compound 3: middle estimate off by 1.1-fold (0.03 log units), on the low side; measured number inside the range.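

In this assay, going by these compounds alone, piperidin-3-yl on the saturated chain carbon bound to an amide-type nitrogen and an aromatic carbon gives the first reading for a ring nitrogen carrying neither methyl nor acetyl. Against 1-methylpiperidin-2-yl the change gives a 1.7-fold higher number from compound 1 to compound 3 (0.22 log units; within the scatter), so this replacement does not separate compound 3 from compound 1 in this test. Against 1-acetylpiperidin-2-yl the change gives an at least 1.4-fold lower number from compound 2 to compound 3 (0.15 log units; that floor lies within the scatter), and the value of compound 2 is a limit, so this step is only a floor and gives no size for the change: the limit of > 84000 nM in this assay, at which 1 of the 3 values shown sits.

Both replacements alter the ring position named in the group and the substituent on the ring nitrogen in a single step, so the share of each in the values remains unresolved. Also open, as far as these compounds go, is how a propanoyl or an ethyl group on the ring nitrogen, or an open-chain amine in place of the piperidine ring, would read in this assay.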